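This account rests on a few compounds, and the source may have more. Where it says the series, first, only, none or still open, it means among the compounds named here.

Of the compounds shown here, three built on a shared core have been tested in a functional assay on the whole organism (artery, strain albino) with Rattus norvegicus as the target, with a stated time of 600 min, at a dose of 10 mg/kg by the oral route; a higher number here means more inhibition at the dose given (going by the name of the read-out), a lower number less inhibition. Compound 1 `CC1=C(C(=O)Nc2ccc(F)cc2)C(c2ccc([N+](=O)[O-])cc2)N=C(SCc2ccc(Cl)cc2)N1` gives 28.2%. Compound 2 `CC1=C(C(=O)Nc2ccc(F)cc2)C(c2ccc([N+](=O)[O-])cc2)N=C(SCc2ccc(F)cc2)N1` carries fluoro in place of chloro on an aromatic carbon and in this assay gives 25.6%; the measured step of a number 2.6 percentage points lower from compound 1 to compound 2 (within the scatter) shows what that single change did. Compound 3 `CC1=C(C(=O)Nc2ccc([N+](=O)[O-])cc2)C(c2cccc([N+](=O)[O-])c2)N=C(SCc2ccc(Cl)cc2)N1` differs from compound 1 in its core, a difference that is not broken down here. In this assay compound 3 gives 26.2%.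

Compound 4 `CC1=C(C(=O)Nc2ccc([N+](=O)[O-])cc2)C(c2cccc([N+](=O)[O-])c2)N=C(SCc2ccc(F)cc2)N1` has not yet been measured. It is built from compound 3 by fluoro in place of chloro on an aromatic carbon, the same change, at the same place on the ring, that leads from compound 1 to compound 2. A step of similar size is expected here, estimated as a number 2.2 percentage points lower from compound 3 to compound 4 (within the scatter), because the step of a number 2.6 percentage points lower from compound 1 to compound 2 (within the scatter) stayed within the scatter. On that basis compound 4 is expected to give about 24% in this assay, most likely falling between 14% and 34%. The measured value will show whether the change behaves the same way on this second core.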

Compound 4, a percentage reported as inhibition, in the whole organism at one dose (the size of the read-out at that dose, not a potency): 30.3%
Beside the measured number, compound 4's estimate is 6.3 percentage points below it; measured number inside the range.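

Putting fluoro in place of chloro on the second core gives, in this assay, a number 4.1 percentage points higher from compound 3 to compound 4 (within the scatter). Set beside the earlier case, the two steps carry opposite signs, but that difference cannot be told from ordinary variation: the same change on two cores in this assay, a number 2.6 percentage points lower (within the scatter) from compound 1 to compound 2 and a number 4.1 percentage points higher (within the scatter) from compound 3 to compound 4, 6.7 percentage points apart, within the scatter of two such steps. On these two cores, the change from 4-chlorobenzyl to 4-fluorobenzyl stays within the scatter each time, which fits a swap that carries over without a visible shift in the read-out; it does not show that the two groups are interchangeable on other cores, or that a small real effect is absent, and two pairs at one dose cannot settle either point.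

The compounds shown carry only chloro or fluoro at this place on the ring, so the outcome with a clearly different group, such as a methoxy group, an amine or a carboxylic acid, remains open. Also open, as far as these compounds go, is whether any group here would move the read-out beyond the scatter at all.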